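The source may report more compounds than this note shows. Statements on the series, on what has been measured and on what is new or still open speak of the compounds shown alone.

Among the measured compounds shown here, compound 1 `O=C(Nc1ccc(Cl)cc1CN1C(=O)c2ccccc2C1=O)c1cccnc1` gives 35000 nM in an assay on CHO cells for positive allosteric modulation of metabotropic glutamate receptor 5 (Homo sapiens), read by FLIPR (on this read-out higher numbers stand for an effect only at larger amounts of compound and lower numbers for an effect already at smaller amounts), the highest of the three numbers measured so far. Compound 3 `O=C(Nc1ccccc1CN1C(=O)c2ccccc2C1=O)c1ccccn1` gives 13900 nM in this assay, a gap to compound 1 that is beyond the scatter. Compound 2 `CCOc1cccc2c1C(=O)N(Cc1cc(Br)ccc1NC(=O)c1ccccn1)C2=O` gives 720 nM, the lowest of the three and far beyond the scatter from compound 1; it differs from compound 1 in more than one place, so its gap cannot be tied to a single change. Compound 4 `COc1ccccc1C(=O)Nc1ccc(Cl)cc1CN1C(=O)c2ccccc2C1=O` has not yet been measured in this assay. It differs from compound 1 in one place: 2-methoxyphenyl in place of pyridin-3-yl on a carbonyl carbon. For the measured compounds named here, no pair of measured compounds isolates this exchange, so the expected step rests on the three numbers alone. Because compound 3 with its other ring on the carbonyl carbon gives 13900 nM, a moderate lowering of the number is expected rather than a rise, with wide uncertainty. Compound 4 is estimated at 15000 nM, between 4000 nM and 50000 nM. The step this estimate means is expected to be a 2.3-fold lower number from compound 1 to compound 4 (0.37 log units; beyond the scatter).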

Compound 4, half-maximal effective concentration: > 100000 nM
Compound 4 was reported as a limit; the forecaster's own chance of this, stated with the estimate: 25%; middle value at least 6.6-fold (0.82 log units) away from the limit.
By their numbers in this assay, from the lowest: compound 2; then compound 3; then compound 1. At a limit, above all of these: compound 4.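

Among the compounds shown here, putting 2-methoxyphenyl in place of pyridin-3-yl on the carbonyl carbon gives an at least 2.8-fold higher number from compound 1 to compound 4 (0.45 log units; beyond the scatter), the first step here that ties a change in the number to this one place. The earlier compounds shown here offered no such single exchange, and this one shows that the group on the carbonyl carbon can by itself move the number upward, beyond the scatter, on a core that already sits high. Compound 4 stands only as a limit in this assay: the limit of > 100000 nM in this assay, at which 1 of the 4 values shown sits.

The compounds shown leave open how large the step really is, and whether it follows the methoxy group or the loss of the ring nitrogen. An unsubstituted phenyl or a 2-methoxypyridin-3-yl on the same carbonyl carbon would separate these two parts of the exchange.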